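This account rests on a few compounds, and the source may have more. Where it says the series, first, only, none or still open, it means among the compounds named here.

Within the data shown here, in a functional assay on KB cells (Homo sapiens) for cytotoxicity (on this read-out higher numbers stand for weaker inhibition and lower numbers for stronger inhibition), compound 2 (`COc1ccc(S(=O)(=O)N2CCc3cccc(NC(C)=O)c32)cc1`) gives 89 nM, the higher of the two numbers so far, while compound 1 (`COc1ccc(S(=O)(=O)N2CCc3cccc(NC(=O)c4ccncc4)c32)cc1`) gives 9.6 nM. Compound 3 (`COc1ccc(S(=O)(=O)N2CCc3cccc(NC(=O)N(C)c4ccccc4)c32)cc1`) differs from compound 2 by methyl(phenyl)amino in place of methyl on a carbonyl carbon. Among the measured compounds shown here, only one measured step bears on this place, a 9.3-fold higher number from compound 1 to compound 2 (0.97 log units; beyond the scatter), with methyl in place of pyridin-4-yl on a carbonyl carbon. As the entering group differs from pyridin-4-yl, a smaller step towards a lower number is expected, estimated as a 2.5-fold lower number from compound 2 to compound 3 (0.41 log units; beyond the scatter). For compound 3 the estimated value is 35 nM, with an expected range of 8 nM to 150 nM.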

Compound 3, half-maximal inhibitory concentration: > 10000 nM
Compound 3 ended at the assay's limit; the forecaster's own chance of this, stated with the estimate: 3%; middle value at least 280-fold (2.45 log units) away from the limit.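

Compound 3 gives > 10000 nM in this assay, a limit and not a number: the limit of > 10000 nM in this assay, at which 1 of the 3 values shown sits. Groups on this carbonyl carbon are therefore not interchangeable: methyl(phenyl)amino gives an at least 110-fold higher number from compound 2 to compound 3 (2.05 log units; beyond the scatter) and an at least 1000-fold higher number from compound 1 to compound 3 (3.01 log units; beyond the scatter), so the two earlier compounds gave no sign of a change this large. As far as these compounds go, the full size of both steps stays unknown.

From the compounds shown here alone, it remains open whether the drop goes with the phenyl ring, the amino nitrogen or its methyl. Phenyl or phenylamino on the same carbonyl carbon would separate these.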